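The source may report more compounds than this note shows. Statements on the series, on what has been measured and on what is new or still open speak of the compounds shown alone.

Compound 1 `CCNC(=O)c1noc(-c2cc(C(C)C)c(O)cc2O)c1-c1cc(COCC(N)=O)no1` carries a carbamoylmethoxy group on a saturated chain carbon bound to an aromatic carbon. In a functional assay on HCT-116 cells (Homo sapiens) for inhibition (on this read-out higher numbers stand for weaker inhibition and lower numbers for stronger inhibition), compound 1 gives 97 nM, the highest of the two numbers recorded so far. For the measured compounds named here, its single measured neighbour is compound 2 `CCNC(=O)c1noc(-c2cc(C(C)C)c(O)cc2O)c1-c1cc(CN(CC)CC)no1`, which in this assay gives 38 nM; the step of a 2.6-fold lower number from compound 1 to compound 2 (0.41 log units; beyond the scatter) brought diethylamino in place of carbamoylmethoxy at that same place.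

Compound 3 `CCNC(=O)c1noc(-c2cc(C(C)C)c(O)cc2O)c1-c1cc(CN2CCCC2)no1` has not yet been measured. It differs from compound 1 as follows: pyrrolidin-1-yl in place of carbamoylmethoxy on a saturated chain carbon bound to an aromatic carbon. Going by the values given here, the one step that bears on this change is the step to compound 2, since diethylamino and pyrrolidin-1-yl both enter at the same place in place of the same carbamoylmethoxy group, and that step, a 2.6-fold lower number from compound 1 to compound 2 (0.41 log units; beyond the scatter), was modest but beyond the scatter. On that basis a drop of similar size is expected for compound 3 in this assay, with the step of a 2.4-fold lower number from compound 1 to compound 3 (0.38 log units; beyond the scatter). Compound 3 is therefore estimated at 40 nM, in a range from 15 nM to 110 nM.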

Compound 3, half-maximal inhibitory concentration: 51 nM
Compound 3: middle estimate off by 1.3-fold (0.11 log units), on the low side; the measured number falls inside the stated range.
By their numbers in this assay, from the lowest: compounds 2, 3 and 1 (each within the scatter of the next, the first and the last beyond it).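

Measured in this assay, the step of a 1.9-fold lower number from compound 1 to compound 3 (0.28 log units; within the scatter) stays inside the scatter, whereas the earlier step of a 2.6-fold lower number from compound 1 to compound 2 (0.41 log units; beyond the scatter) lies beyond it, so only diethylamino, and not pyrrolidin-1-yl, is separated from carbamoylmethoxy on this saturated chain carbon bound to an aromatic carbon. The direct comparison of the two amines gives the step of a 1.3-fold higher number from compound 2 to compound 3 (0.13 log units; within the scatter), also within the scatter, so tying the two ethyl groups into the five-membered ring of pyrrolidin-1-yl leaves no change that this read-out can resolve, and compounds 2 and 3 cannot be told apart here. The three compounds therefore show a difference at this place only between compound 1 and compound 2, and nothing available explains the result.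

The compounds shown leave open whether a piperidin-1-yl or morpholin-4-yl group, or a primary amine, would fall with compound 2 and compound 3 at this same place. They also leave open how a carboxylic acid in place of the carbamoylmethoxy amide, or a longer chain between the amine and the aromatic carbon, would read in this assay on the same core.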